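Sulfonyl substituents on a benzoxazole sulfonamide core

This account rests on a few compounds, and the source may have more. Where it says the series, first, only, none or still open, it means among the compounds named here.

Compounds measured so far:
compound 1 `C=Cc1ccc(S(=O)(=O)Nc2ccc3oc(-c4ccccc4)nc3c2)cc1` gives > 100000 nM
compound 2 `COc1cccc(S(=O)(=O)Nc2ccc3oc(-c4ccccc4)nc3c2)c1` gives > 100000 nM
compound 3 `O=S(=O)(Nc1ccc2oc(-c3ccccc3)nc2c1)c1cccs1` gives 90000 nM

In an assay on cells for inhibition of HSP60/HSP10 (Homo sapiens), with a stated time of 60 min (a higher number here means a weaker inhibitor, a lower number a stronger inhibitor), compound 1 reaches only the limit of the assay, > 100000 nM, not a number. Compound 2 likewise stands at a limit, > 100000 nM. Going by the values given here, compound 3 is the single compound with a measured number, 90000 nM, and it therefore stands at the only readable point among the three; the step from compound 1 to compound 2 cannot be read because both sit at the limit of > 100000 nM in this assay, at which 2 of the 3 values shown sit.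

Among the compounds with values here, the steps that bear on the sulfonyl substituent are an at least 1.1-fold lower number from compound 1 to compound 3 (0.04 log units; that floor lies within the scatter) and an at least 1.1-fold lower number from compound 2 to compound 3 (0.04 log units; that floor lies within the scatter), each a floor that lies within the scatter, so they show at most that compound 3 is not weaker than the two limit compounds.

Compound 4 `CS(=O)(=O)Nc1ccc2oc(-c3ccccc3)nc2c1` has not yet been measured. It differs from compound 3 by methyl in place of thiophen-2-yl on a sulfonyl sulfur. Within the data shown here, no measured step involves a methyl on the sulfonyl sulfur, so the only guide is that every change at this position so far left the number at or near the limit. Compound 4 is therefore expected to show no step beyond the scatter, a 1.1-fold higher number from compound 3 to compound 4 (0.05 log units; within the scatter), with a fair chance of only a limit. The estimate for compound 4 in this assay is 100000 nM, within 30000 nM to 300000 nM.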

Compound 4, half-maximal inhibitory concentration: > 100000 nM
Compound 4 gave a limit, no number (the forecaster's own chance of this, stated with the estimate: 60%); the middle value sits exactly at the limit.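

In this assay, methyl in place of thiophen-2-yl on a sulfonyl sulfur gives an at least 1.1-fold higher number from compound 3 to compound 4 (0.04 log units; that floor lies within the scatter), so this change brings no measurable gain, though the true size of the step stays hidden behind the floor. Compound 4 is the first compound shown with no ring on the sulfonyl sulfur, and it falls at a limit just as compounds 1 and 2 do, so limit values here occur both with and without a ring at this place. The steps from compound 1 and from compound 2 to compound 4 cannot be read because both ends of each sit at the same limit: the limit of > 100000 nM in this assay, at which 3 of the 4 values shown sit.

From the compounds shown here alone, whether any group on the sulfonyl sulfur can give a number clearly beyond the scatter remains open. The compounds shown do not tell how an amine, a carboxylic acid or a longer chain would behave there.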